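The source may report more compounds than this note shows. Statements on the series, on what has been measured and on what is new or still open speak of the compounds shown alone.

Measured compounds:
- compound 1, `NC1=NC2(CCSCC2)N(OCCCOc2cccc(Cl)c2)C(N)=N1`: "not determined" (no result reported) in an assay on isolated protein for inhibition of Dihydrofolate reductase (Homo sapiens), read by spectrophotometry, using NADPH, with stated times of 5 s and 6 min; on this read-out lower numbers stand for stronger inhibition and higher numbers for weaker inhibition
- compound 2, `NC1=NC2(CCOCC2)N(OCCCOc2ccc(Cl)cc2)C(N)=N1`: 33.6 nM
- compound 3, `NC1=NC2(CCSCC2)N(OCCCOc2ccc(Br)cc2)C(N)=N1`: 6.46 nM

Compound 1 carries no result in this assay. Of the two numbers that exist, compound 2 has the higher one, and compound 3 a number well below it, a gap beyond the usual scatter; the two differ in more than one place, so the numbers say only where each stands. Compound 4, `NC1=NC2(CCOCC2)N(OCCCOc2ccc(Cl)c(Cl)c2)C(N)=N1`, is not yet measured and differs from compound 2 by one change: chloro in place of hydrogen on an aromatic carbon. Among the measured compounds shown here, with no measured pair showing the effect of this change, the expected step from compound 2 to compound 4 is modest and toward a lower number, a 2.2-fold lower number from compound 2 to compound 4 (0.35 log units; beyond the scatter). The estimate for compound 4 is 15 nM, within a range from 5 nM to 50 nM.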

Compound 4, half-maximal inhibitory concentration: 8.23 nM
The estimate for compound 4 lay 1.8-fold (0.26 log units) above the measured number, within the range that was stated.
By their numbers in this assay, from the lowest: compounds 3 and 4 (each within the scatter of the next); then compound 2.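

In this assay, among the compounds shown here, the change from 4-chlorophenyl to 3,4-dichlorophenyl gives a 4.1-fold lower number from compound 2 to compound 4 (0.61 log units; beyond the scatter) and is the first single change that can be read here. It shows that a chloro group on this aromatic carbon, ortho to the existing chloro group, goes with stronger inhibition on the core of compound 2. No measurement shown here gives a reason for this step.

From the compounds shown here alone, whether a fluoro group, a methyl group or a methoxy group on this carbon would give a similar step remains open. So does whether the added chloro group would have the same effect on the core of compound 3.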